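Swapping a Trifluoromethyl for a Methyl on the Ring

The source may hold more compounds than are shown below. What is called first, only, known or untested is meant among the compounds shown, and "the series" means these compounds.

Of the compounds shown here, three sharing one core have been tested in an assay on isolated protein for binding affinity to Adrenergic receptor alpha-1 (Rattus norvegicus), read by radioligand binding, in the presence of a further agent that is not named here; on this read-out lower numbers stand for stronger inhibition and higher numbers for weaker inhibition. Compound 1 `Fc1cccc2c1C=C(CC1CN=CN1)CC2` gives 501 nM, and compound 2 `Fc1ccc2c(c1)C=C(CC1CN=CN1)CC2` gives 251 nM. Compound 3 `FC(F)(F)c1ccc2c(c1)C=C(CC1CN=CN1)CC2` gives 1260 nM, which is the highest of the three numbers; compound 1 is the nearest to it and compound 2 the furthest, both beyond the usual scatter of this assay. Within the data shown here, the one single-point change on record here is the move from compound 2 to compound 3, which produced a 5.0-fold higher number from compound 2 to compound 3 (0.70 log units; beyond the scatter).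

Compound 4 `Cc1ccc2c(c1)C=C(CC1CN=CN1)CC2` is not yet measured. It differs from compound 3 by methyl in place of trifluoromethyl on an aromatic carbon. This change partly undoes the earlier move, in that the trifluoromethyl leaves again, though what enters is methyl rather than the fluoro of compound 2. Among the measured compounds shown here, that earlier move is the only step that bears on this one, and it was of modest size and beyond the scatter. For the measured compounds named here, a shift back toward lower numbers is therefore expected in this assay, but of uncertain size, since no compound with a methyl at that place has been measured.

For compound 4 the expected step is a 3.2-fold lower number from compound 3 to compound 4 (0.50 log units; beyond the scatter). The estimate for compound 4 in this assay is 400 nM, with a likely range from 150 nM to 1200 nM.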

Compound 4, inhibition constant: 398 nM
Beside the measured number, compound 4's estimate is 1.0-fold (0.00 log units) above it; measured number inside the range.
By their numbers in this assay, from the lowest: compounds 2, 4 and 1 (each within the scatter of the next); then compound 3.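

In this assay, replacing trifluoromethyl with methyl on this aromatic carbon gives a 3.2-fold lower number from compound 3 to compound 4 (0.50 log units; beyond the scatter) and so brings the number back down, which shows that the higher number of compound 3 is not a general result of replacing fluoro at this place. Fluoro and methyl cannot be told apart here, since the change between them gives a 1.6-fold higher number from compound 2 to compound 4 (0.20 log units; within the scatter) and stays within the scatter; among the three groups tested at this place, only trifluoromethyl stands apart, with the two others giving numbers that lie within the scatter of each other. Nothing measured here accounts for why trifluoromethyl behaves differently from methyl and fluoro at this place.

Going by these compounds, it remains open whether other groups on this carbon, such as a methoxy group, an amine or a longer chain like ethyl, would stay with methyl and fluoro or move toward trifluoromethyl. On these data alone, it is also open whether the same swap from trifluoromethyl to methyl would give a similar step on the carbon that carries fluoro in compound 1.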